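This account rests on a few compounds, and the source may have more. Where it says the series, first, only, none or still open, it means among the compounds named here.

In a functional assay on KB cells (Homo sapiens) for cytotoxicity (on this read-out higher numbers stand for an effect only at larger amounts of compound and lower numbers for an effect already at smaller amounts), compound 2 (`C=Cc1ccccc1/C=C/C(O)=C1/C(=O)C(C)=C(OC)C(C)(C)C1=O`) gives 1.1 ug/mL. Within the data shown here, that sits level, within the scatter, with compound 1 (`COC1=C(C)C(=O)/C(=C(O)/C=C/c2ccc(C)cc2)C(=O)C1(C)C`) at 1.9 ug/mL, the only other number so far. Compound 3 (`COC1=C(C)C(=O)/C(=C(O)/C=C/c2ccco2)C(=O)C1(C)C`) keeps the shared core and changes only the group on a double-bonded chain carbon bound to a double-bonded chain carbon: furan-2-yl in place of 2-vinylphenyl on a double-bonded chain carbon bound to a double-bonded chain carbon. Among the measured compounds shown here, one measured step bears on this place, a 1.7-fold lower number from compound 1 to compound 2 (0.24 log units; within the scatter), and it stays within the scatter. It is weak guidance, since neither measured compound carries a furan-2-yl group, and a single exchange between two six-membered aromatic rings says little about a five-membered one. No step beyond the scatter is therefore expected in this assay, and no direction can be firmly predicted. The estimate amounts to an expected 1.6-fold higher number from compound 2 to compound 3 (0.21 log units; within the scatter). For compound 3 the expected value is 1.8 ug/mL, with an estimated range of 0.7 ug/mL to 5 ug/mL.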

Compound 3, concentration for half-maximal effect: 8.8 ug/mL
Beside the measured number, compound 3's estimate is 4.9-fold (0.69 log units) below it; measured number above the stated range.
By their numbers in this assay, from the lowest: compounds 2 and 1 (each within the scatter of the next); then compound 3.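

In this assay the group on a double-bonded chain carbon bound to a double-bonded chain carbon now proves able to shift the read-out, which the two six-membered aromatic rings alone had not shown: furan-2-yl in place of 2-vinylphenyl gives an 8.0-fold higher number from compound 2 to compound 3 (0.90 log units; beyond the scatter) and furan-2-yl in place of 4-methylphenyl gives a 4.6-fold higher number from compound 1 to compound 3 (0.67 log units; beyond the scatter) as well. Among these three compounds, then, the five-membered aromatic ring with its oxygen needs a larger amount of compound for the same effect than either carbon-only six-membered ring. No accompanying data speak to what lies behind this shift.

Still open, as far as these compounds go, is whether ring size or the ring oxygen goes with the higher number, a question that a thiophen-2-yl group, with sulfur in place of the oxygen, would bear on. Also open, from the compounds shown here alone, is how a six-membered aromatic ring carrying an amine or a carboxylic acid would behave at this place.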